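This account rests on a few compounds, and the source may have more. Where it says the series, first, only, none or still open, it means among the compounds named here.

Measured compounds:
- compound 1, `N#Cc1cnc(NCc2cnccc2C(F)(F)F)cc1NC[C@H]1C[C@H](O)C1`: > 10000 nM
- compound 2, `COc1ncncc1CNc1cc(N[C@H]2CC[C@@H](O)CC2)c(C#N)cn1`: 800 nM
- compound 3, `N#Cc1cnc(NCc2cncnc2OCC(F)F)cc1N[C@H]1CC[C@@H](O)CC1`: 90 nM

In an assay on isolated protein for inhibition of protein kinase C delta type (Homo sapiens), read by TR-FRET, with a stated time of 2 h (on this read-out higher numbers stand for weaker inhibition and lower numbers for stronger inhibition), compound 1 gives only a limit, (the limit of > 10000 nM in this assay, at which 1 of the 3 values shown sits); no number is known for it. Compound 4, `CC1(C)[C@@H](C(N)=O)C[C@H]1Nc1cc(NCc2cnccc2C(F)(F)F)ncc1C#N`, differs from compound 1 by 3-carbamoyl-2,2-dimethylcyclobutyl in place of (3-hydroxycyclobutyl)methyl on a nitrogen on an aromatic ring. Among the compounds with values here, the single measured step, an 8.9-fold lower number from compound 2 to compound 3 (0.95 log units; beyond the scatter), concerns a different part of the shared core and does not bear on this change; the side of the core altered here has no measured step at all. Compound 4 also carries the ring directly on the nitrogen, as compound 2 and compound 3 do, while compound 1 has a one-carbon link. Against a limit, no size can be set for the step; compound 4 is estimated at 1500 nM (150 nM to 10000 nM), a step of an at least 6.6-fold lower number from compound 1 to compound 4 (0.82 log units; beyond the scatter) being expected.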

Compound 4, half-maximal inhibitory concentration: 160 nM
The estimate for compound 4 lay 9.4-fold (0.97 log units) above the measured number; low and high end bracket the measured number.
By their numbers in this assay, from the lowest: compounds 3 and 4 (each within the scatter of the next); then compound 2. At a limit, above all of these: compound 1.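

Compound 1 gives > 10000 nM, a limit of the assay and not a number. In this assay, the group on this nitrogen on an aromatic ring matters greatly, with an at least 62-fold lower number from compound 1 to compound 4 (1.79 log units; beyond the scatter) and the rest of the structure unchanged. This position also carries the larger 3-carbamoyl-2,2-dimethylcyclobutyl with inhibition still measurable.

Which part of the change carries the step stays open: the ring directly on the nitrogen, the carbamoyl and the two methyls enter together. A plain cyclobutyl on the nitrogen, or a carboxylic acid in place of the carbamoyl, would help separate these.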